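The compounds below may be only part of what the source reports. "The series", "measured", "known", "first", "only" and "open" are said of these compounds alone.

Working notes on the series. Among the compounds with values here, in a functional assay on CWR22R cells (Homo sapiens) for antiproliferative activity, read by CCK-8 assay, with a stated time of 6 days (on this read-out higher numbers stand for weaker inhibition and lower numbers for stronger inhibition), compound 1 (`N#Cc1ccc(N2CCc3cc(-c4cncnc4)ccc3C2)cc1C(F)(F)F`) has the entry "not determined" (no result reported), so compound 2 (`N#Cc1ccc(N2CCc3cc(-c4ccncc4)ccc3C2)cc1C(F)(F)F`), at 6940 nM, carries the only number and has nothing to be ranked against. Compound 3 (`N#Cc1ccc(N2CCc3cc(-c4cccnc4)ccc3C2)cc1C(F)(F)F`) has pyridin-3-yl in place of pyridin-4-yl on an aromatic carbon. Within the data shown here, no measured step exists to size this change, so no shift beyond the usual scatter is expected, in either direction. The expected step is a 1.2-fold lower number from compound 2 to compound 3 (0.06 log units; within the scatter). The estimated value for compound 3 is 6000 nM, with an expected range of 2500 nM to 15000 nM.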

Compound 3, half-maximal inhibitory concentration: 4790 nM
For compound 3 the middle estimate is 1.3-fold (0.10 log units) above the measured one; low and high end bracket the measured number.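

In this assay, within the data shown here, pyridin-3-yl in place of pyridin-4-yl on an aromatic carbon gives a 1.4-fold lower number from compound 2 to compound 3 (0.16 log units; within the scatter), the only measured step at this position. On this step, the two pyridine attachments cannot be told apart in this read-out. No measurement bearing on a cause accompanies this result.

As far as these compounds go, whether pyridin-2-yl, a morpholine or a carboxylic acid at this place would give a step beyond the scatter remains open. From the compounds shown here alone, the contribution of the nitrile and trifluoromethyl groups of the shared core also remains open.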